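From chloro to methoxy on the longest chain

This account rests on a few compounds, and the source may have more. Where it says the series, first, only, none or still open, it means among the compounds named here.

Values in a functional assay on HCT-116 cells (Homo sapiens) for antiproliferative activity, read by MTT assay, with a stated time of 48 h (a lower number here means a stronger inhibitor, a higher number a weaker inhibitor), for the three measured compounds:
Compound 1 `CCCCC(CCO)n1cnc2c(OC)ncnc21` gives > 50000 nM (a limit of the assay, not a number)
Compound 2 `CCCCCCCC(CCO)n1cnc2c(OC)ncnc21` gives 15300 nM
Compound 3 `CCCCCCCCCC(CCO)n1cnc2c(Cl)ncnc21` gives 890 nM

Compound 3 holds the lowest number shown at 890 nM and stands beyond the scatter from compound 2, its nearest neighbour. Compound 4 `CCCCCCCCCC(CCO)n1cnc2c(OC)ncnc21` is compound 3 with methoxy in place of chloro on an aromatic carbon. For the measured compounds named here, no measured step isolates this swap. Going by the values given here, the only measured step, an at least 3.2-fold lower number from compound 1 to compound 2 (0.51 log units; beyond the scatter), keeps methoxy and changes the chain, so it bears on the swap only indirectly. Among the compounds with values here, with methoxy and a shorter chain, compound 2 gives 15300 nM and the expectation for compound 4 therefore lies between that value and the one of compound 3. The estimated step is a 3.9-fold higher number from compound 3 to compound 4 (0.59 log units; beyond the scatter) in this assay, towards a higher number and well beyond the scatter. Compound 4 is expected at 3500 nM, within an estimated range from 1000 nM to 12000 nM.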

Compound 4, half-maximal inhibitory concentration: 2530 nM
Estimate against measurement, compound 4: 1.4-fold (0.14 log units) above, within the range that was stated.
By their numbers in this assay, from the lowest: compound 3; then compound 4; then compound 2. At a limit, above all of these: compound 1.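

In this assay the swap can now be read with the chain held constant, methoxy in place of chloro on an aromatic carbon giving a 2.8-fold higher number from compound 3 to compound 4 (0.45 log units; beyond the scatter). With methoxy kept, lengthening the chain also continues to count at this end of the series, giving a 6.0-fold lower number from compound 2 to compound 4 (0.78 log units; beyond the scatter). Compound 1 stands at a limit of the assay, not a number, so an at least 19-fold lower number from compound 1 to compound 4 (1.29 log units; beyond the scatter) is only a bound: the limit of > 50000 nM in this assay, at which 1 of the 4 values shown sits.

As far as these compounds go, whether chloro keeps its lower number on shorter chains remains open. So does how an amine on that aromatic carbon, or a longer chain, would compare.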